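A Longer Acyl Chain on a Sugar Ester

The source may report more compounds than this note shows. Statements on the series, on what has been measured and on what is new or still open speak of the compounds shown alone.

The series rests on a shared core carrying an ester, read in a functional assay on K562 cells (Homo sapiens) for inhibition; a lower number here means a stronger inhibitor, a higher number a weaker inhibitor. Compound 1 `CC(=O)OC1C(C(O)CO)OC2OC(C)(C)OC21` bears an acetyl group and in this assay gives 3800000 nM. Compound 2 `CC1(C)OC2OC(C(O)CO)C(OC(=O)C(C)(C)C)C2O1` in this assay gives 1500000 nM. That is the lowest of the two numbers recorded so far, and compound 1 stands nearest to it, separated by the step of a 2.5-fold lower number from compound 1 to compound 2 (0.40 log units; beyond the scatter).

Compound 3 `CC(C)(C)CC(=O)OC1C(C(O)CO)OC2OC(C)(C)OC21` differs from compound 2 by a single change: neopentyl in place of tert-butyl on a carbonyl carbon. Among the compounds with values here, the only measured step that bears on this change is a 2.5-fold lower number from compound 1 to compound 2 (0.40 log units; beyond the scatter), which concerns the same carbonyl carbon and went toward a lower number when a larger acyl group replaced a smaller one. That step was modest, and the present change is of a similar kind but smaller in scope, so any movement is expected to be small and uncertain in direction. Compound 3 is therefore expected to give about 1100000 nM, between 400000 nM and 3000000 nM. For compound 3 the expected step is a 1.4-fold lower number from compound 2 to compound 3 (0.13 log units; within the scatter), which may well lie within the scatter.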

Compound 3, half-maximal inhibitory concentration: 1200000 nM
Compound 3: the middle estimate sits 1.1-fold (0.04 log units) below what was measured, and the stated range covers the measured number.
By their numbers in this assay, from the lowest: compounds 3 and 2 (each within the scatter of the next); then compound 1.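

In this assay, placing neopentyl where tert-butyl stood on the carbonyl carbon gives a 1.3-fold lower number from compound 2 to compound 3 (0.10 log units; within the scatter), so this position does not separate these two acyl groups, and compound 2 and compound 3 cannot be put in order. The acetyl ester stands apart from the neopentyl ester as well, with a 3.2-fold lower number from compound 1 to compound 3 (0.50 log units; beyond the scatter), which means that compound 1 now differs beyond the scatter from both of the other esters, while the change from tert-butyl to neopentyl adds no measurable shift of its own. Nothing available explains why the acetyl ester differs from the other two or why the last change leaves the number within the scatter.

The compounds shown leave open whether a longer straight chain, a benzoyl group, or an acyl group carrying an amine or a carboxylic acid on the same carbonyl carbon would move the number beyond the scatter from compound 2 and compound 3. They also leave open what an amide in place of the ester would do on the shared core.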